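Swapping a bromobenzyl for a decyl chain on the triazole

The source may hold more compounds than are shown below. What is called first, only, known or untested is meant among the compounds shown, and "the series" means these compounds.

Measured compounds:
compound 1 `O=C(CN1CCC(Cc2ccccc2)CC1)Nc1ccc(C(=O)/C=C/c2cn(Cc3ccc(Br)cc3)nn2)cc1` — 41900 nM
compound 2 `O=C(CN1CCN(c2ccccc2)CC1)Nc1ccc(C(=O)/C=C/c2cn(Cc3ccc(Br)cc3)nn2)cc1` — 79700 nM
compound 3 `CC(C)(C)OC(=O)N1CCN(CC(=O)Nc2ccc(C(=O)/C=C/c3cn(Cc4ccc(Br)cc4)nn3)cc2)CC1` — 18900 nM

Of the compounds shown here, three share one core and have been tested in a functional assay on HeLa cells (Homo sapiens) for inhibition, read by MTT assay; a higher number here means a weaker inhibitor, a lower number a stronger inhibitor. Compound 1 gives 41900 nM there, and compound 2 gives 79700 nM, the two numbers lying within the scatter of each other. Compound 3 gives 18900 nM, a lower number than compound 1 that lies beyond the scatter. Going by the values given here, the only counted step, a 4.2-fold lower number from compound 2 to compound 3 (0.62 log units; beyond the scatter), concerns the group on the amine nitrogen in the ring.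

Compound 4 `CCCCCCCCCCn1cc(/C=C/C(=O)c2ccc(NC(=O)CN3CCC(Cc4ccccc4)CC3)cc2)nn1` differs from compound 1 elsewhere: nonyl in place of 4-bromophenyl on a saturated chain carbon bound to an aromatic nitrogen. Among the compounds with values here, no measured pair changes this part of the molecule, so the step from compound 2 to compound 3 gives no guidance here, and the data contain nothing that points in either direction. The expectation is therefore a number close to that of compound 1, with a wide range around it. The estimated step is a 1.0-fold lower number from compound 1 to compound 4 (0.02 log units; within the scatter). Compound 4 is expected to give about 40000 nM in this assay, between 10000 nM and 160000 nM.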

Compound 4, half-maximal inhibitory concentration: 71700 nM
Compound 4: middle estimate off by 1.8-fold (0.25 log units), on the low side, and the stated range covers the measured number.
By their numbers in this assay, from the lowest: compound 3; then compounds 1, 4 and 2 (each within the scatter of the next).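

Going by these compounds alone, compound 4 gives the first reading at this position: in this assay, the change shows a 1.7-fold higher number from compound 1 to compound 4 (0.23 log units; within the scatter). Replacing 4-bromobenzyl with decyl removes both the aromatic ring and the bromine, yet this assay cannot tell the two compounds apart. At least on the core of compound 1, then, a ring at this position is not needed for a number of this size, and no measured property here accounts for the two groups reading alike.

Going by these compounds, it remains open whether a shorter chain such as butyl, or a plain benzyl without the bromine, would read the same on this core. On these data alone, it is also open whether decyl would read like 4-bromobenzyl when paired with the tert-butoxycarbonyl group of compound 3.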